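Butyl for sec-butyl on sulfur in compound 2

This account rests on a few compounds, and the source may have more. Where it says the series, first, only, none or still open, it means among the compounds named here.

In an ADME assay on MT4 cells (Homo sapiens) for activation, read by MTT assay (a lower number here means that less compound is tolerated, a higher number that more compound is tolerated), compound 2 `CCC(C)Sc1nc(C(C)c2c(F)cccc2Cl)c(C)c(=O)[nH]1` gives > 1500 nM, which is a limit and not a number. Compound 1 `CCCCSc1nc(Cc2c(F)cccc2Cl)c(C)c(=O)[nH]1` gives > 73000 nM, also a limit. Compound 3 `CCCCSc1nc(C(C)c2c(F)cccc2Cl)c(C)c(=O)[nH]1` differs from compound 2 by butyl in place of sec-butyl on a sulfur, with butyl in place of sec-butyl on a sulfur. For the measured compounds named here, no measured step covers this change. An upward move is expected, with an estimated step that the limit leaves unreadable from compound 2 to compound 3. That expectation rests on compound 1 and its limit of > 73000 nM. For compound 3 the expected value is 30000 nM, within an estimated range of 3000 nM to 100000 nM.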

Compound 3, half-maximal cytotoxic concentration: > 1500 nM
Compound 3 ended at the assay's limit; the forecaster's own chance of this, stated with the estimate: 60%; the middle value does not contradict the limit.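

For the compounds shown here, compound 1, compound 2 and compound 3 all stand as limits in this assay, so no step among them can be read. From the compounds shown here alone, whether butyl in place of sec-butyl on the sulfur, or methyl in place of hydrogen on the saturated chain carbon, changes the tolerated concentration stays open.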